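Replacing the Ester Chain of Compound 3 with an Amine

A few compounds are considered here, and "the series" means these few. Any claim that something is new, unique, unknown or untested is made for them only; others in the source may bear on it.

Compound 1 `CC(=O)OCc1ccc2oc(=O)c(C(=O)Oc3cccc(Br)c3)cc2c1`: 11.8%
Compound 2 `CCCC(=O)OCc1ccc2oc(=O)c(C(=O)Oc3cccc(Br)c3)cc2c1`: 24.7%
Compound 3 `CCCCCC(=O)OCc1ccc2oc(=O)c(C(=O)Oc3cccc(Br)c3)cc2c1`: 33.9%

Three compounds share one core and differ only in the chain of the ester. In a functional assay on HT-1080 cells (Homo sapiens), read by transwell migration, with a stated time of 24 h, tested at 10 uM (on this read-out lower numbers stand for a stronger effect and higher numbers for a weaker effect at the one concentration tested), compound 1 gives 11.8%, compound 2 gives 24.7%, and compound 3 gives 33.9%. Compound 3 has the highest of the three numbers. The step of a number 9.2 percentage points higher from compound 2 to compound 3 (within the scatter) stays within the scatter, so compound 2 and compound 3 cannot be told apart; the step of a number 22.1 percentage points higher from compound 1 to compound 3 (beyond the scatter) lies beyond it, as does the step of a number 12.9 percentage points higher from compound 1 to compound 2 (beyond the scatter). Read together, a longer chain went with a higher number in these three, that is, a weaker effect at the one concentration tested.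

Compound 4 `NCc1ccc2oc(=O)c(C(=O)Oc3cccc(Br)c3)cc2c1` is made from compound 3 by a different kind of change: amino in place of (pentylcarbonyl)oxy on a saturated chain carbon bound to an aromatic carbon. Within the data shown here, no measured step removes the ester group, so the three steps bear on it only loosely. They show that the shortest chain, in compound 1, gave the lowest number, and compound 4 carries no chain at all. A move towards lower numbers in this assay is therefore expected, but with wide uncertainty. The step of a number 15.9 percentage points lower from compound 3 to compound 4 (beyond the scatter) is expected to be a drop beyond the scatter. Compound 4 is estimated at 18%, in a range from 5% to 38%.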

Compound 4, a percentage reported as activity, at one concentration (the size of the read-out at that concentration, not a potency): 63.6%
The estimate for compound 4 lay 45.6 percentage points below the measured number, and the stated range ends below it.
By their numbers in this assay, from the lowest: compound 1; then compounds 2 and 3 (each within the scatter of the next); then compound 4.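

In this assay, the step of a number 29.7 percentage points higher from compound 3 to compound 4 (beyond the scatter) is joined by a number 38.9 percentage points higher from compound 2 to compound 4 (beyond the scatter) and by a number 51.8 percentage points higher from compound 1 to compound 4 (beyond the scatter) when amino takes the place of the ester group on this saturated chain carbon bound to an aromatic carbon. The ester series alone pointed the other way, with the shortest chain, in compound 1, giving the lowest number, yet compound 4 carries the smallest group here, 1 heavy atom against 8 in (pentylcarbonyl)oxy, and has the highest number of the four, that is, the weakest effect at the one concentration tested. A short group at this place is therefore not enough for a low number, and no measurement at hand explains why the amine stands apart from the esters.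

The compounds shown do not separate the loss of the ester from the arrival of the amine, and a plain alcohol at this place, or an amide built on the same amine, would help tell the two apart. Also open, on these data alone, is how a dimethylamino group at this place would compare with amino.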